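Swapping Methyl for Fluoro: An Expected Loss of Potency

The source may report more compounds than this note shows. Statements on the series, on what has been measured and on what is new or still open speak of the compounds shown alone.

Four compounds were examined in a functional assay on HeLa cells (Homo sapiens) for antiproliferative activity, read by MTT assay, with a stated time of 48 h; on this read-out lower numbers stand for stronger inhibition and higher numbers for weaker inhibition. Compound 1 `Cc1cnc(Nc2ccc(S(C)(=O)=O)cc2)nc1Nc1nc2ccc(Cl)cc2s1` gives 4180 nM in this assay. Compound 2 `CS(=O)(=O)c1ccc(Nc2ncc(F)c(Nc3nc4ccc(Cl)cc4s3)n2)cc1` differs from it by fluoro in place of methyl on an aromatic carbon. In this assay compound 2 reaches only a limit of the assay, > 50000 nM. The change therefore gives an at least 11-fold higher number from compound 1 to compound 2 (1.07 log units; beyond the scatter), its floor set by the limit of > 50000 nM in this assay, at which 1 of the 3 values shown sits. Compound 3 `COc1ccc2nc(Nc3nc(Nc4ccc(S(N)(=O)=O)cc4)ncc3C)sc2c1` carries a different core; the difference between the two cores is not broken down here. In this assay compound 3 gives 36700 nM. Compound 4 `COc1ccc2nc(Nc3nc(Nc4ccc(S(N)(=O)=O)cc4)ncc3F)sc2c1` is not yet measured and differs from compound 3 by fluoro in place of methyl on an aromatic carbon, the same kind of change as before. Because the earlier change produced an at least 11-fold higher number from compound 1 to compound 2 (1.07 log units; beyond the scatter), a step of similar size is expected here, a 4.1-fold higher number from compound 3 to compound 4 (0.61 log units; beyond the scatter). Compound 4 is thus expected to give 150000 nM, quite possibly reported only as a limit.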

Compound 4, half-maximal inhibitory concentration: 13000 nM
Compound 4: the middle estimate sits 12-fold (1.06 log units) above what was measured, outside the stated range (below it).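

In this assay, fluoro in place of methyl gives a 2.8-fold lower number from compound 3 to compound 4 (0.45 log units; beyond the scatter), so the same swap does not carry over from one core to the other, and its direction even reverses: the same change on two cores in this assay, an at least 11-fold higher number (1.07 log units; beyond the scatter) from compound 1 to compound 2 and a 2.8-fold lower number (0.45 log units; beyond the scatter) from compound 3 to compound 4, at least 33-fold (1.52 log units) apart, beyond the scatter of two such steps. The value of compound 2 is only a limit: the limit of > 50000 nM in this assay, at which 1 of the 4 values shown sits. These two pairs show that the outcome of the swap depends on the core around it, but they do not show which difference between the core of compound 1 and the core of compound 3 is responsible.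

The compounds shown leave open how other groups, such as a nitrile or an amine, would behave on this same aromatic carbon. They also leave open whether those groups would rank in the same order on both cores.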